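A few compounds are considered here, and "the series" means these few. Any claim that something is new, unique, unknown or untested is made for them only; others in the source may bear on it.

Measured so far:
- compound 1, `CCC(C(=O)N1CCN(c2ccccc2Cl)CC1)N1C(=O)CCC1=O`: 50%
- compound 2, `CC(C(=O)N1CCN(c2ccccc2F)CC1)N1C(=O)CCC1=O`: 50%
- compound 3, `CC(C(=O)N1CCN(c2cccc(F)c2)CC1)N1C(=O)CCC1=O`: 75%

In a functional assay on the whole organism (strain Swiss) with Mus musculus as the target, in the maximal electroshock model, with a stated time of 1 h, at a dose of 300 mg/kg by the intraperitoneal route (on this read-out lower numbers stand for a weaker effect and higher numbers for a stronger effect at the one dose given), compound 3 stands highest of the three, with compound 1 and compound 2 both the same distance below it, beyond the scatter. The next compound, compound 4 `CC(C(=O)N1CCN(c2ccccc2Cl)CC1)N1C(=O)CCC1=O`, differs from compound 3 in one place: 2-chlorophenyl in place of 3-fluorophenyl on an amine nitrogen in a ring.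

For the measured compounds named here, only one measured step bears directly on this change. It is a number 25 percentage points higher from compound 2 to compound 3 (beyond the scatter), where moving the fluorine from the 2-position to the 3-position of the phenyl ring raised the number. Compound 4 goes the other way, back to a group on the 2-position, and brings chlorine instead of fluorine. Going by the values given here, no single step covers that swap, but compound 1, which also carries 2-chlorophenyl, gives 50%, and compound 2, with 2-fluorophenyl, gives 50%, the same number. A fall from compound 3 is therefore expected, about a number 25 percentage points lower from compound 3 to compound 4 (beyond the scatter). Compound 4 is estimated at 50%, between 25% and 75%.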

Compound 4, a percentage reported as activity, at one dose (the size of the read-out at that dose, not a potency): 25%
For compound 4 the middle estimate is 25 percentage points above the measured one; low and high end bracket the measured number.
By their numbers in this assay, from the lowest: compound 4; then compounds 1 and 2 (each within the scatter of the next); then compound 3.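

In this assay, for the compounds shown here, the earlier compounds offered no step that changed the halogen alone; chloro in place of fluoro on an aromatic carbon gives a number 25 percentage points lower from compound 2 to compound 4 (beyond the scatter) (beyond the scatter as printed), so the halogen itself matters here. The chain matters too: hydrogen in place of methyl on a saturated chain carbon gives a number 25 percentage points lower from compound 1 to compound 4 (beyond the scatter) in this series. Going by these compounds alone, changing the ring group in both respects, with 2-chlorophenyl in place of 3-fluorophenyl, gives a number 50 percentage points lower from compound 3 to compound 4 (beyond the scatter) and is the largest step so far.

Nothing presented here explains why any of these changes lowers the number. Still open, from the compounds shown here alone, is how a phenyl ring with no halogen, a ring carrying a methoxy group, or a longer chain would behave on this core.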